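Swapping sec-butyl for 5-(diethylamino)pentyl on the shared core

The compounds below may be only part of what the source reports. "The series", "measured", "known", "first", "only" and "open" are said of these compounds alone.

In a functional assay on DU-145 cells (Homo sapiens) for antiproliferative activity, read by WST assay, with a stated time of 3 days (on this read-out lower numbers stand for stronger inhibition and higher numbers for weaker inhibition), two compounds built on one core have so far given no number. Compound 1 `CCCCCCCOc1c(-c2cc(OC)c(OC)c(OC)c2)oc2ccccc2c1=O` gives > 50000 nM, which is a limit of the assay and not a number. Compound 2 `CCC(C)Oc1c(-c2cc(OC)c(OC)c(OC)c2)oc2ccccc2c1=O` gives > 50000 nM, which is also a limit. Compound 2 therefore stands at the limit of > 50000 nM in this assay, at which 2 of the 2 values shown sit. Exchanging heptyl for sec-butyl is a step that the two limits leave unreadable from compound 1 to compound 2, so no measured size can be carried forward.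

Compound 3 `CCN(CC)CCCCCOc1c(-c2cc(OC)c(OC)c(OC)c2)oc2ccccc2c1=O` carries 5-(diethylamino)pentyl in place of sec-butyl on an oxygen on an aromatic ring. Among the compounds with values here, the one measured step joins two chains made only of carbon, whereas the entering chain also holds nitrogen, so that step is a poor guide here. A move towards stronger inhibition is expected, but this rests on the structural change alone, and compound 3 could still stay at the limit. The expected change is an at least 8.3-fold lower number from compound 2 to compound 3 (0.92 log units; beyond the scatter), a rough estimate. For compound 3 the estimated value is 6000 nM, with an expected range from 1500 nM to 30000 nM.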

Compound 3, half-maximal inhibitory concentration: 33400 nM
Compound 3: the middle estimate sits 5.6-fold (0.75 log units) below what was measured; measured number outside the range, above it.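

In this assay, compound 3 is the only compound on the shared core that gives a number rather than a limit: the limit of > 50000 nM in this assay, at which 2 of the 3 values shown sit.

On an oxygen on an aromatic ring, the chain that holds a nitrogen is therefore the one that brings a readable value here, which neither all-carbon chain, heptyl or sec-butyl, has done, and exchanging sec-butyl for 5-(diethylamino)pentyl gives an at least 1.4-fold lower number from compound 2 to compound 3 (0.17 log units; that floor lies within the scatter), while diethylamino in place of ethyl at the end of the heptyl chain gives an at least 1.4-fold lower number from compound 1 to compound 3 (0.17 log units; that floor lies within the scatter). Each step is only a floor, so the true size could be larger, but what can be read so far does not clear the usual scatter.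

The compounds shown do not separate the part played by the nitrogen from that of the chain's length, as compound 3 is the only chain here that ends in an amine. A shorter or longer chain ending in diethylamino, a chain ending in a ring amine such as piperidine, or one ending in a carboxylic acid would help to tell these apart.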